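This account rests on a few compounds, and the source may have more. Where it says the series, first, only, none or still open, it means among the compounds named here.

Of the compounds shown here, two have been measured in a functional assay on HT-29 cells (Homo sapiens) for inhibition, read by MTT assay, with a stated time of 48 h; on this read-out higher numbers stand for weaker inhibition and lower numbers for stronger inhibition. Compound 1 `COc1cc(/C=C/c2ccc(NC(=O)/C=C/c3cc(OC)c(OC)c(OC)c3)cc2)cc(OC)c1` gives 1820 nM in this assay. For the measured compounds named here, compound 2 `COc1cc(/C=C/c2ccc(NC(=O)/C=C/c3ccc(F)cc3)cc2)cc(OC)c1` gives 11600 nM in this assay, the highest of the two numbers recorded, and compound 1 is its only and nearest neighbour, at a gap that lies beyond the usual scatter. The step now followed leads to compound 3 `COc1cc(/C=C/c2ccc(NC(=O)/C=C/c3ccc(O)c(O)c3)cc2)cc(OC)c1`, which carries the change (3,4-dihydroxyphenyl in place of 4-fluorophenyl on a double-bonded chain carbon bound to a double-bonded chain carbon). Going by the values given here, no measured pair in this set differs in exactly this way, so the expectation rests only on the two numbers given. Among the compounds with values here, a decrease from compound 2 rather than an increase is expected, of moderate size, because the only other measured compound, compound 1, gives 1820 nM. The estimated step of a 2.6-fold lower number from compound 2 to compound 3 (0.41 log units; beyond the scatter) expresses this expectation. Compound 3 is therefore estimated to give 4500 nM, with a likely range from 1500 nM to 13000 nM.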

Compound 3, half-maximal inhibitory concentration: 1560 nM
The estimate for compound 3 lay 2.9-fold (0.46 log units) above the measured number; the range from low to high includes it.
By their numbers in this assay, from the lowest: compounds 3 and 1 (each within the scatter of the next); then compound 2.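

In this assay, 3,4-dihydroxyphenyl in place of 4-fluorophenyl on a double-bonded chain carbon bound to a double-bonded chain carbon gives a 7.4-fold lower number from compound 2 to compound 3 (0.87 log units; beyond the scatter), so this place clearly responds to a change of group. Compound 1 at 1820 nM and compound 3 at 1560 nM lie within the scatter of each other, which shows that two different groups here give numbers that cannot be told apart, while 4-fluorophenyl in compound 2 stands apart from both. Nothing measured here accounts for the step.

The compounds shown leave open whether a single hydroxyl group, as in 4-hydroxyphenyl, would give the same number as 3,4-dihydroxyphenyl. As far as these compounds go, how a ring at this place bearing an amine or a carboxylic acid would read also remains open.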